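A few compounds are considered here, and "the series" means these few. Any claim that something is new, unique, unknown or untested is made for them only; others in the source may bear on it.

Measured so far in a functional assay (aorta) with Rattus norvegicus as the target; a higher number here means a weaker inhibitor, a lower number a stronger inhibitor:
- Compound 1 `N#Cc1c(-c2ccccc2)cc(-c2ccccc2O)[nH]c1=O`: 0.95 nM
- Compound 2 `N#Cc1c(-c2ccccc2Br)cc(-c2ccccc2O)nc1O`: 17000 nM

Compound 2 has the higher of the two numbers, which makes it the weaker inhibitor, and its gap to compound 1 lies well beyond the scatter. Compound 3 `COc1ccccc1-c1cc(-c2ccccc2O)nc(O)c1C#N` puts methoxy in place of bromo on an aromatic carbon, ortho to a large group, turning 2-bromophenyl into 2-methoxyphenyl (methoxy in place of bromo on an aromatic carbon). Within the data shown here, no measured pair shows what this swap does in this assay, so only a moderate fall in the number is expected, and with wide uncertainty. The expected change is an 8.5-fold lower number from compound 2 to compound 3 (0.93 log units; beyond the scatter). The estimate for compound 3 is 2000 nM, with an expected range of 30 nM to 40000 nM.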

Compound 3, half-maximal inhibitory concentration: 12 nM
Compound 3: middle estimate off by 170-fold (2.22 log units), on the high side; the measured number lies below the stated range.
By their numbers in this assay, from the lowest: compound 1; then compound 3; then compound 2.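

On an aromatic carbon ortho to a large group, methoxy in place of bromo gives a 1400-fold lower number from compound 2 to compound 3 (3.15 log units; beyond the scatter) in this assay and shows that this single position can govern the measured number. The swap adds only one heavy atom and one hydrogen-bond acceptor, yet the step lies far beyond the scatter. Nothing available here explains this step.

As far as these compounds go, whether fluoro, ethoxy or an amine on this carbon would give a number nearer to compound 2 or to compound 3 remains open. Also open, from the compounds shown here alone, is whether methoxy would give a similar step on another carbon of this ring.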